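From 3-methylphenyl to 4-fluorophenyl on a shared core

A few compounds are considered here, and "the series" means these few. Any claim that something is new, unique, unknown or untested is made for them only; others in the source may bear on it.

Four compounds share one core and differ only in the group on a carbon with a double bond to nitrogen. In a physicochemical assay for lipophilicity (a lower number here means a more polar compound, a higher number a more lipophilic compound), compound 1 `COc1ccc(C2=NO[C@]3(C2)C(=O)O[C@@H]2[C@H]3CC[C@H](C)[C@]3(O)C=CC(=O)[C@@]23C)cc1OC`, which carries 3,4-dimethoxyphenyl, gives 1.06. Compound 2 `C[C@H]1CC[C@@H]2[C@@H](OC(=O)[C@]23CC(c2ccccc2Cl)=NO3)[C@]2(C)C(=O)C=C[C@@]12O`, with 2-chlorophenyl, gives 2.09. Compound 3 `Cc1cccc(C2=NO[C@]3(C2)C(=O)O[C@@H]2[C@H]3CC[C@H](C)[C@]3(O)C=CC(=O)[C@@]23C)c1`, with 3-methylphenyl, gives 1.86, which lies within the scatter of compound 2 and well clear of compound 1.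

Replacing the 3,4-dimethoxyphenyl accounts for the two larger steps, a number 1.03 log units higher from compound 1 to compound 2 (beyond the scatter) and a number 0.80 log units higher from compound 1 to compound 3 (beyond the scatter). Exchanging the other two groups gives only a number 0.23 log units lower from compound 2 to compound 3 (within the scatter).

Compound 4 `C[C@H]1CC[C@@H]2[C@@H](OC(=O)[C@]23CC(c2ccc(F)cc2)=NO3)[C@]2(C)C(=O)C=C[C@@]12O` has not yet been measured. It differs from compound 3 as follows: 4-fluorophenyl in place of 3-methylphenyl on a carbon with a double bond to nitrogen. Among the measured compounds shown here, no measured step involves 4-fluorophenyl, so the guidance is indirect. For the measured compounds named here, the change swaps one substituted phenyl for another, and the closest precedent is a number 0.23 log units lower from compound 2 to compound 3 (within the scatter), not the larger steps that start from compound 1. A small change in this assay is therefore expected, and the estimated step is a number 0.21 log units lower from compound 3 to compound 4 (within the scatter). Compound 4 is expected to give 1.65, with an estimated range of 1.3 to 2.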

Compound 4, partition coefficient: 1.58
Compound 4: the middle estimate sits 0.07 log units above what was measured; measured number inside the range.
By their numbers in this assay, from the lowest: compound 1; then compounds 4, 3 and 2 (each within the scatter of the next, the first and the last beyond it).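

In this assay the exchange of 3-methylphenyl for 4-fluorophenyl gives a number 0.28 log units lower from compound 3 to compound 4 (within the scatter) and so stays small at this position, on the carbon with a double bond to nitrogen. Among the compounds shown here, the same group nevertheless opens a gap that the earlier compounds did not show, with a number 0.51 log units lower from compound 2 to compound 4 (beyond the scatter) even though 2-chlorophenyl and 3-methylphenyl had stayed within the scatter of each other, so the three groups other than 3,4-dimethoxyphenyl no longer read as a single level. Compound 1 remains the lowest of the four, and the new group also clears it, with a number 0.52 log units higher from compound 1 to compound 4 (beyond the scatter) added to the two earlier steps beyond the scatter that start from compound 1.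

Nothing in the available data accounts for these differences. Still open, on these data alone, is how an amine, a carboxylic acid or a longer alkyl chain in place of the substituted phenyl would read in this assay, and whether a step of this size would hold on any other part of the shared core, as all four compounds differ only in this one group.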